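Fluorophenyl Exchange on the Amine Ring: Compound 3 to 4

The compounds below may be only part of what the source reports. "The series", "measured", "known", "first", "only" and "open" are said of these compounds alone.

Of the compounds shown here, three sharing one core have been measured in a functional assay on CHO cells with adenosine receptor A1 (Homo sapiens) as the target, read by cAMP accumulation and immunoassay, with a stated time of 6 min, tested at 1 uM; a higher number here means a weaker effect of the compound at the concentration tested, a lower number a stronger effect. Compound 1 `CC(C)N1CCN(Cc2csc(N)c2C(=O)c2ccc(Cl)cc2)CC1` gives 7.3%. Compound 2 `Nc1scc(CN2CCN(c3cccc(Cl)c3Cl)CC2)c1C(=O)c1ccc(Cl)cc1` gives -57%, and compound 3 `Nc1scc(CN2CCN(c3cc(F)cc(F)c3)CC2)c1C(=O)c1ccc(Cl)cc1` gives -66%. Compound 3 holds the lowest of the three numbers; its nearest neighbour is compound 2, whose value sits within the scatter of it, while compound 1 lies far off, as a number 73.3 percentage points lower from compound 1 to compound 3 (beyond the scatter) shows. The step of a number 64.3 percentage points lower from compound 1 to compound 2 (beyond the scatter) is of similar size, whereas a number 9 percentage points lower from compound 2 to compound 3 (within the scatter) stays within the scatter.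

Compound 4 `Nc1scc(CN2CCN(c3c(F)cc(F)cc3F)CC2)c1C(=O)c1ccc(Cl)cc1` is not yet measured. It differs from compound 3 in one place: 2,4,6-trifluorophenyl in place of 3,5-difluorophenyl on an amine nitrogen in a ring. The measured step that bears most directly on this change is a number 9 percentage points lower from compound 2 to compound 3 (within the scatter), an exchange of one substituted phenyl for another on the same amine nitrogen, which did not leave the scatter. The large steps from compound 1 concern an isopropyl giving way to an aryl group and so say little about an exchange between two aryl groups. Compound 4 is therefore expected to show a number 6 percentage points higher from compound 3 to compound 4 (within the scatter), no step beyond the scatter. The estimate for compound 4 in this assay is -60%, with a range from -88% to -28%.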

Compound 4, a percentage reported as activity, at one concentration (the size of the read-out at that concentration, not a potency): -56%
For compound 4 the middle estimate is 4 percentage points below the measured one; the range from low to high includes it.
By their numbers in this assay, from the lowest: compounds 3, 2 and 4 (each within the scatter of the next); then compound 1.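

In this assay, exchanging 3,5-difluorophenyl for 2,4,6-trifluorophenyl on the amine nitrogen gives a number 10 percentage points higher from compound 3 to compound 4 (within the scatter), and exchanging 2,3-dichlorophenyl for the same group gives a number 1 percentage points higher from compound 2 to compound 4 (within the scatter), so this position accommodates a third substituted phenyl, with three fluorines, without the read-out leaving the scatter of the other two. The step from the isopropyl compound, a number 63.3 percentage points lower from compound 1 to compound 4 (beyond the scatter), is large, and it joins the two earlier steps of this kind, so all three aryl compounds now stand well apart from compound 1, with none of the listed compounds going against this. Nothing in the data shown explains why these three differently substituted phenyl groups cannot be told apart here.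

The compounds shown leave open whether a phenyl carrying a carboxylic acid, an amine or a methoxy group would stay with the aryl compounds, and whether a benzyl group or a longer alkyl chain on the same nitrogen would fall with them or nearer compound 1. They also leave open whether the effects of compound 2, compound 3 and compound 4 would still be indistinguishable at other concentrations; the read-out comes from a single concentration.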